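This account rests on a few compounds, and the source may have more. Where it says the series, first, only, none or still open, it means among the compounds named here.

Compound 3 `Clc1ccc(C2=NN(c3nc(-c4ccc(Br)cc4)cs3)C(c3cccs3)C2)cc1` gives 1450 nM in a functional assay on WM 266-4 cells (Homo sapiens) for antiproliferative activity, read by MTT assay, with a stated time of 48 h (a lower number here means a stronger inhibitor, a higher number a weaker inhibitor), the lowest of the three measured numbers. Its nearest neighbour is compound 1 `COc1ccc(C2=NN(c3nc(-c4ccc(Br)cc4)cs3)C(c3cccs3)C2)cc1`, which gives 5870 nM in this assay, and the furthest is compound 2 `Cc1ccc(C2=NN(c3nc(-c4ccc(Br)cc4)cs3)C(c3cccs3)C2)cc1`, which gives 18400 nM. The measured steps are a 4.0-fold lower number from compound 1 to compound 3 (0.61 log units; beyond the scatter), a 13-fold lower number from compound 2 to compound 3 (1.10 log units; beyond the scatter) and a 3.1-fold higher number from compound 1 to compound 2 (0.50 log units; beyond the scatter); all three change the group on the phenyl ring that sits on the shared core, and the two involving chloro are beyond the scatter.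

Compound 4 `COc1ccc(-c2csc(N3N=C(c4ccc(Cl)cc4)CC3c3cccs3)n2)cc1` differs from compound 3 by methoxy in place of bromo on an aromatic carbon, on an aromatic carbon of a six-membered aromatic ring of carbon only, para to a large group. Going by the values given here, this change lies on the other phenyl ring, the one not varied among compounds 1, 2 and 3, so no measured step bears on it directly. Among the compounds with values here, the only guidance is indirect: in the measured series a halogen is replaced by methoxy between compound 3 and compound 1, and there the methoxy compound gave the higher number. Going by these compounds, whether the same holds on the second ring is unknown. A modest rise in this assay is therefore expected for compound 4, a 2.4-fold higher number from compound 3 to compound 4 (0.38 log units; beyond the scatter), with an estimated value of 3500 nM, expected to fall between 900 nM and 14000 nM.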

Compound 4, half-maximal inhibitory concentration: 1310 nM
The estimate for compound 4 lay 2.7-fold (0.43 log units) above the measured number; the measured number falls inside the stated range.
By their numbers in this assay, from the lowest: compounds 4 and 3 (each within the scatter of the next); then compound 1; then compound 2.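

In this assay, the swap of 4-bromophenyl for 4-methoxyphenyl gives a 1.1-fold lower number from compound 3 to compound 4 (0.04 log units; within the scatter), so at this position, on an aromatic carbon para to a large group, the two groups cannot be told apart by their numbers. The earlier compounds shown here varied only the other phenyl ring, where a 4.0-fold lower number from compound 1 to compound 3 (0.61 log units; beyond the scatter) is a change from methoxy to chloro beyond the scatter; methoxy therefore does not carry the same result on both rings, although the halogen is chloro in that step and bromo in this one. Nothing available here bears on why this swap leaves the number within the scatter.

With only bromo and methoxy shown at this position, the compounds leave open whether an amine, a carboxylic acid or a longer chain there would also stay within the scatter of compound 3. They also leave open whether the large differences seen on the other ring among methoxy, methyl and chloro would hold with 4-methoxyphenyl in place of 4-bromophenyl.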